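Furan in place of methoxynaphthalene on the saturated carbon

The source may report more compounds than this note shows. Statements on the series, on what has been measured and on what is new or still open speak of the compounds shown alone.

Measured compounds:
compound 1 `N#CC1=C(N)N(c2ccc(S(N)(=O)=O)cc2)C2=C(C(=O)CCC2)C1/C=C/c1ccccc1`, 40%
compound 2 `COc1cc(CC2C(C#N)=C(N)N(c3ccc(S(N)(=O)=O)cc3)C3=C2C(=O)CCC3)ccc1O`, 90%
compound 3 `COc1ccc2ccccc2c1C1C(C#N)=C(N)N(c2ccc(S(N)(=O)=O)cc2)C2=C1C(=O)CCC2`, 70%

In a functional assay on Ehrlich cells (Mus musculus) for antiproliferative activity, read by trypan blue exclusion, with a stated time of 2 h, tested at 50 ug/mL (on this read-out lower numbers stand for a weaker effect and higher numbers for a stronger effect at the one concentration tested), compound 3 stands second highest of the three numbers; compound 2 lies higher, compound 1 lower. Compound 4 `Cc1ccoc1C1C(C#N)=C(N)N(c2ccc(S(N)(=O)=O)cc2)C2=C1C(=O)CCC2` differs from compound 3 by 3-methylfuran-2-yl in place of 2-methoxynaphthalen-1-yl on a saturated ring carbon. The steps that touch this position are a number 30 percentage points higher from compound 1 to compound 3 (beyond the scatter) and a number 20 percentage points lower from compound 2 to compound 3 (beyond the scatter), both modest and beyond the scatter, showing the group on the saturated ring carbon moves this assay over a wide span. For the measured compounds named here, no measured step introduces a five-membered aromatic ring here, so the direction is uncertain. A modest fall is estimated, a number 10 percentage points lower from compound 3 to compound 4 (within the scatter). Compound 4 is therefore expected to give 60%, within 30% to 85%.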

Compound 4, a percentage reported as activity, at one concentration (the size of the read-out at that concentration, not a potency): 40%
Beside the measured number, compound 4's estimate is 20 percentage points above it, within the range that was stated.
By their numbers in this assay, from the lowest: compounds 1 and 4 (each within the scatter of the next); then compound 3; then compound 2.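

In this assay the first five-membered aromatic ring at this saturated ring carbon, 3-methylfuran-2-yl, gives a number 30 percentage points lower from compound 3 to compound 4 (beyond the scatter) and a number 50 percentage points lower from compound 2 to compound 4 (beyond the scatter). It therefore falls short of both 2-methoxynaphthalen-1-yl and 4-hydroxy-3-methoxybenzyl. Against 2-phenylethenyl it gives no change at the digits printed from compound 1 to compound 4 (within the scatter), so two quite different groups share the low end of the series.

Nothing available accounts for the fall. The compounds shown also leave open whether it follows the furan ring or its methyl group, which a plain furan-2-yl or a thiophene ring would help to separate.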